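This account rests on a few compounds, and the source may have more. Where it says the series, first, only, none or still open, it means among the compounds named here.

Measured so far in a functional assay on THP-1 cells (Homo sapiens) for cytotoxicity, read by MTT assay, with a stated time of 24 h; a lower number here means a stronger inhibitor, a higher number a weaker inhibitor: compound 1 `COc1ccc(/C=C2\CN(C)C/C(=C\c3ccccc3F)C2=O)cc1` gives 15400 nM; compound 2 `CN1C/C(=C\c2ccc(C(C)(C)C)cc2)C(=O)/C(=C/c2ccccc2F)C1` gives 13400 nM; compound 3 `CN1C/C(=C\c2ccc(C#N)cc2)C(=O)/C(=C/c2ccccc2F)C1` gives 810 nM.

Compound 3 stands lowest of the three numbers. Its nearest neighbour is compound 2 (a 17-fold lower number from compound 2 to compound 3 (1.22 log units; beyond the scatter)) and its furthest is compound 1 (a 19-fold lower number from compound 1 to compound 3 (1.28 log units; beyond the scatter)), while the remaining pair is close (a 1.1-fold lower number from compound 1 to compound 2 (0.06 log units; within the scatter)). Compound 4 `CN1C/C(=C\c2ccc(Br)cc2)C(=O)/C(=C/c2ccc(C#N)cc2)C1` differs from compound 3 by 4-bromophenyl in place of 2-fluorophenyl on a double-bonded chain carbon bound to a double-bonded ring carbon. Among the measured compounds shown here, none of the measured steps bears on this change: all three alter the group on the other aromatic ring of the shared core, and that part is held fixed here. No direction can therefore be read from the series, and no step beyond the scatter is expected. Compound 4 is expected to give 1000 nM, between 300 nM and 4000 nM. That estimate means an expected step of a 1.2-fold higher number from compound 3 to compound 4 (0.09 log units; within the scatter).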

Compound 4, half-maximal inhibitory concentration: 4400 nM
The estimate for compound 4 lay 4.4-fold (0.64 log units) below the measured number; the measured number lies above the stated range.
By their numbers in this assay, from the lowest: compound 3; then compound 4; then compounds 2 and 1 (each within the scatter of the next).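

The position on the double-bonded chain carbon bound to a double-bonded ring carbon is not silent in this assay: with the 4-cyanophenyl group kept, 4-bromophenyl in place of 2-fluorophenyl gives a 5.4-fold higher number from compound 3 to compound 4 (0.73 log units; beyond the scatter). Among the compounds shown here, both groups count the same heavy atoms, so this step is not a change in that count, and the earlier compounds, which all kept 2-fluorophenyl, could not show it. No measurement here accounts for the step.

The halogen and its place on the ring change together, so the compounds shown cannot separate the two. Going by these compounds, how an amine or a carboxylic acid on this ring would read also stays open.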